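A Methoxyphenyl Replaces Chlorophenyl on an Aromatic Nitrogen

This account rests on a few compounds, and the source may have more. Where it says the series, first, only, none or still open, it means among the compounds named here.

Of the compounds shown here, three have so far been measured in a functional assay on A549 cells (Homo sapiens) for antiproliferative activity, read by MTT assay, with a stated time of 48 h; on this read-out higher numbers stand for weaker inhibition and lower numbers for stronger inhibition. Compound 1 `N#CC1=C(N)Oc2c(c3nc4ccccc4nc3c3ccccc23)C12C(=O)N(Cc1cnnn1-c1ccc([N+](=O)[O-])cc1)c1ccccc12` is reported only as a limit of the assay, > 50000 nM, so no number stands for it. Compound 2 `Cc1cccc(-n2nncc2CN2C(=O)C3(C(C#N)=C(N)Oc4c(N)cc5nc6ccccc6nc5c43)c3ccccc32)c1` gives 12300 nM in this assay, and compound 3 `N#CC1=C(N)Oc2c(N)cc3nc4ccccc4nc3c2C12C(=O)N(Cc1cnnn1-c1ccccc1Cl)c1ccccc12` gives 29800 nM. Compound 3 thus holds the highest of the two numbers; its nearest neighbour is compound 2, separated by the step of a 2.4-fold higher number from compound 2 to compound 3 (0.38 log units; beyond the scatter), a modest change brought about by exchanging the aryl group on the aromatic nitrogen.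

The unmeasured compound 4 `COc1ccc(-n2nncc2CN2C(=O)C3(C(C#N)=C(N)Oc4c(N)cc5nc6ccccc6nc5c43)c3ccccc32)cc1` differs from compound 3 in one place: 4-methoxyphenyl in place of 2-chlorophenyl on an aromatic nitrogen. Among the compounds with values here, the only measured step that bears on this change is a 2.4-fold higher number from compound 2 to compound 3 (0.38 log units; beyond the scatter), which shows that exchanging one aryl group for another on this nitrogen shifts the number only modestly. A step of similar or smaller size is therefore expected in this assay, with no firm direction, since the two measured aryl groups both differ from the 4-methoxyphenyl.

Compound 4 is accordingly expected to give about 20000 nM in this assay, most likely between 8000 nM and 50000 nM. That estimate amounts to an expected step of a 1.5-fold lower number from compound 3 to compound 4 (0.17 log units; within the scatter).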

Compound 4, half-maximal inhibitory concentration: > 50000 nM
Compound 4 gave a limit, no number; the forecaster's own chance of this, stated with the estimate: 20%; middle value at least 2.5-fold (0.39 log units) from the limit.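

In this assay, compound 4 gives a limit of the assay and not a number, so it can be placed only from below: the limit of > 50000 nM in this assay, at which 2 of the 4 values shown sit. The exchange of 2-chlorophenyl for 4-methoxyphenyl is an at least 1.6-fold higher number from compound 3 to compound 4 (0.22 log units; that floor lies within the scatter), and that floor alone does not separate the two aryl groups, although the true step may be larger. Within the data shown here, the exchange of 3-methylphenyl for 4-methoxyphenyl is an at least 4.0-fold higher number from compound 2 to compound 4 (0.60 log units; beyond the scatter), which is beyond the scatter and shows what the earlier compounds did not: on this aromatic nitrogen of the five-membered ring, the choice of aryl group can move the number by more than a 2.4-fold higher number from compound 2 to compound 3 (0.38 log units; beyond the scatter), and can take it out of the range the assay reads.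

The compounds shown leave open how far beyond the limit compound 4 lies, and so the full size of both new steps, and they give no ground for tying the loss to the oxygen, to the methoxy group as a whole or to where it sits. As far as these compounds go, it also stays open whether an amine or a carboxylic acid in place of the methoxy group on the phenyl ring would bring a readable number back.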